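The compounds below may be only part of what the source reports. "The series", "measured", "known", "first", "only" and "open" are said of these compounds alone.

Compound 1 `C=C(c1ccc(OC)cc1NC(=O)CNCC)c1ccc(OC)c2c1OC(C)(C)C=C2` and compound 3 `C=C(c1ccc(OC)cc1NC(=O)CN(C)C)c1ccc(OC)c2c1OC(C)(C)C=C2` share one core; compound 2 `C=C(c1cc(OC)c(OC)c(OC)c1)c1ccc(OC)cc1NC(=O)CNCC` and the unmeasured compound 4 `C=C(c1cc(OC)c(OC)c(OC)c1)c1ccc(OC)cc1NC(=O)CN(C)C` share another, and the difference between the two cores is not broken down here. In a functional assay on MCF7 cells (Homo sapiens) for antiproliferative activity, read by MTT assay, with a stated time of 48 h (on this read-out lower numbers stand for stronger inhibition and higher numbers for weaker inhibition), compound 1 gives 2100 nM, compound 3 gives 500 nM and compound 2 gives 860 nM. Compound 2 stands apart from compound 1 by a gap beyond the scatter, and from compound 3 by a gap within it, so no order between compound 2 and compound 3 is claimed. The change from compound 1 to compound 3, (dimethylamino in place of ethylamino on a saturated chain carbon bound to a carbonyl carbon), produced a 4.2-fold lower number from compound 1 to compound 3 (0.62 log units; beyond the scatter). The change from compound 2 to compound 4 is the same change, (dimethylamino in place of ethylamino on a saturated chain carbon bound to a carbonyl carbon), on the other core. For compound 4 a step of a 3.7-fold lower number from compound 2 to compound 4 (0.57 log units; beyond the scatter) is expected in this assay, resting on compound 1 and compound 3 through a 4.2-fold lower number from compound 1 to compound 3 (0.62 log units; beyond the scatter); with a single instance of the change, the size is held with some reserve. Compound 4 is estimated at 230 nM in this assay, within an expected range from 100 nM to 550 nM.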

Compound 4, half-maximal inhibitory concentration: 390 nM
Beside the measured number, compound 4's estimate is 1.7-fold (0.23 log units) below it; measured number inside the range.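

In this assay, dimethylamino in place of ethylamino on a saturated chain carbon bound to a carbonyl carbon gives a 2.2-fold lower number from compound 2 to compound 4 (0.34 log units; beyond the scatter), the same direction as on the core of compound 1. On these two cores the change therefore carries over in direction, and the two step sizes cannot be told apart: the same change on two cores in this assay, a 4.2-fold lower number (0.62 log units; beyond the scatter) from compound 1 to compound 3 and a 2.2-fold lower number (0.34 log units; beyond the scatter) from compound 2 to compound 4, 1.9-fold (0.28 log units) apart, within the scatter of two such steps This rests on one pair per core, so it shows neither a rule for other cores in the series nor why the change lowers the number.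

Still open, going by these compounds, is how the series responds to other amines at this place, such as methylamino, diethylamino, pyrrolidine or morpholine, and whether any of them would separate the effect of the hydrogen-bond donor that leaves with ethylamino from that of the added carbon arrangement. Also open, on these data alone, is whether the step persists on a third core or with a longer chain between the carbonyl and the amine.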